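Ethoxy for difluoromethoxy in a cytotoxicity-silent series

The source may hold more compounds than are shown below. What is called first, only, known or untested is meant among the compounds shown, and "the series" means these compounds.

Three measured compounds share one core and have been run in an ADME assay on SW480 cells (Homo sapiens) for cytotoxicity, read by MTT assay, with a stated time of 72 h; on this read-out higher numbers stand for weaker inhibition and lower numbers for stronger inhibition. Compound 1 `O=C(Nc1ccc(OC(F)F)cc1)c1cccc(/C=C2\CC(=O)N(c3ccccc3)C2=O)c1` returns only a limit, > 100000 nM, in this assay. Compound 2 `CCCCNC(=O)c1cccc(/C=C2\CC(=O)N(Cc3ccccc3)C2=O)c1` likewise returns a limit, > 100000 nM. Compound 3 `COc1ccc(NC(=O)c2cccc(CC3CC(=O)N(c4ccc(C)cc4)C3=O)c2)cc1` also sits at a limit, > 100000 nM. Where compound 1 stands is thus a limit and not a number, and nothing separates it from the other two, since (the limit of > 100000 nM in this assay, at which 3 of the 3 values shown sit).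

The unmeasured compound 4 `CCOc1ccc(NC(=O)c2cccc(/C=C3\CC(=O)N(c4ccccc4)C3=O)c2)cc1` differs from compound 1 in one place: ethyl in place of difluoromethyl on an oxygen on an aromatic ring. Among the compounds with values here, no step between measured compounds is available, so the size of this change cannot be calibrated against anything; the only guide is that every value obtained so far is a limit.

The step expected is a step that the limit leaves unreadable from compound 1 to compound 4, that is, none beyond the scatter of this assay. Compound 4 is accordingly expected to be reported as a limit again rather than as a number. Compound 4 is estimated at 150000 nM in this assay, with a range from 40000 nM to 500000 nM.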

Compound 4, half-maximal inhibitory concentration: 91500 nM
Beside the measured number, compound 4's estimate is 1.6-fold (0.21 log units) above it; the range from low to high includes it.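

In this assay, ethyl in place of difluoromethyl on an oxygen on an aromatic ring yields the only reading shown that is a number rather than a limit: compound 4 gives 91500 nM. Compound 1 gives > 100000 nM, which is a limit of the assay and not a number. The change reads as an at least 1.0-fold lower number from compound 1 to compound 4 (0.03 log units; that floor lies within the scatter), so it is bounded from one side only, its true size remains unknown, and no shift beyond the scatter can be claimed at this position, where the series otherwise offers only: the limit of > 100000 nM in this assay, at which 3 of the 4 values shown sit.

On these data alone, it remains open whether a number at this position is particular to ethyl, or whether a longer chain such as butyl on the same oxygen, or an amine in place of the ethoxy group, would also give a number in this assay. Within the data shown here, compound 2 and compound 3 differ from compound 4 in more than one place and give no step to it, so the effect of the other parts of the shared core on this read-out also remains open.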